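Chain extension in a series sitting at the assay limit

The source may report more compounds than this note shows. Statements on the series, on what has been measured and on what is new or still open speak of the compounds shown alone.

compound 1 `CCCCc1cc2ccccc2nc1-c1cc(-c2ccccc2)no1` — > 100000 nM
compound 2 `CCCCCc1cc2ccccc2nc1-c1cc(-c2ccccc2)no1` — > 100000 nM
compound 3 `CCCCc1cc2ccccc2nc1-c1cc(-c2ccc(C)cc2)no1` — > 100000 nM

In a functional assay on MDA-MB-231 cells (Homo sapiens) for inhibition, read by MTT assay, with a stated time of 24 h (a higher number here means a weaker inhibitor, a lower number a stronger inhibitor), compound 1 reaches only the limit > 100000 nM, a limit of the assay and not a number. Compound 2 likewise stops at the limit > 100000 nM. Compound 3 also gives only the limit > 100000 nM.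

Compound 2 differs from compound 1 by methyl in place of hydrogen on a saturated chain carbon, four bonds along the chain from an aromatic carbon; the step that the two limits leave unreadable from compound 1 to compound 2 stays unreadable because of the limit of > 100000 nM in this assay, at which 3 of the 3 values shown sit. Compound 3 differs from compound 1 by methyl in place of hydrogen on an aromatic carbon, and the step that the two limits leave unreadable from compound 1 to compound 3 is equally unreadable because of the limit of > 100000 nM in this assay, at which 3 of the 3 values shown sit.

Compound 4 `CCCCCc1cc2ccccc2nc1-c1cc(-c2ccc(C)cc2)no1` is not yet measured. It differs from compound 3 by methyl in place of hydrogen on a saturated chain carbon, four bonds along the chain from an aromatic carbon, the same change as from compound 1 to compound 2, at the same place. The step for compound 4, a step that the limit leaves unreadable from compound 3 to compound 4, is expected to be flat. That expectation rests on the limit of > 100000 nM in this assay, at which 3 of the 3 values shown sit, and on the unreadable a step that the two limits leave unreadable from compound 1 to compound 2. Compound 4 is therefore estimated at 150000 nM, most probably again only a limit.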

Compound 4, half-maximal inhibitory concentration: > 100000 nM
Compound 4 was reported as a limit; the forecaster's own chance of this, stated with the estimate: 90%; the middle value does not contradict the limit.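

Compound 4 yields no readable step from compound 2 or from compound 3, because all the values remain at one limit of the assay: the limit of > 100000 nM in this assay, at which 4 of the 4 values shown sit.

The compounds shown leave open whether either methyl change alters inhibition at all.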